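The compounds below may be only part of what the source reports. "The series", "measured", "known", "first", "only" and "open" are said of these compounds alone.

Three compounds sharing one core were taken into an ADME assay on J774.A1 cells (Mus musculus) for cytotoxicity, read by MTT assay, with a stated time of 72 h (a higher number here means that more compound is tolerated, a lower number that less compound is tolerated), and only one of them yields a number. There, compound 1 (`COc1cc(-c2cc(-c3ccc(C4NC(=O)c5ccccc5N4)cc3)nc(N)n2)cc(OC)c1OC`) gives 103000 nM as its reading. Compound 2 (`Nc1nc(-c2ccc(F)cc2)cc(-c2ccc(C3NC(=O)c4ccccc4N3)cc2)n1`) has "not determined" (no result reported) as its entry. Compound 3 (`Nc1nc(-c2ccc(C3NC(=O)c4ccccc4N3)cc2)cc(-c2ccccc2Cl)n1`) likewise has "not determined" (no result reported) as its entry, so it cannot be placed above or below compound 1 on the numbers available, and it shares this lack of a single number with compound 2.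

The next compound is compound 4 (`Nc1nc(-c2ccc(Br)cc2)cc(-c2ccc(C3NC(=O)c4ccccc4N3)cc2)n1`), still unmeasured in this assay. It carries 4-bromophenyl in place of 2-chlorophenyl on an aromatic carbon of the six-membered aromatic ring with 2 nitrogen, and the difference counts as 4-bromophenyl in place of 2-chlorophenyl on an aromatic carbon in full.

Going by the values given here, no step between measured compounds exists, so the size of this change cannot be read from the data, and neither can its direction. No step beyond the usual scatter is expected. Among the compounds with values here, the only anchor is compound 1 at 103000 nM in this series, so the expectation stays near that reading with a wide margin.

Compound 4 is estimated at 80000 nM (expected range 25000 nM to 200000 nM).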

Compound 4, half-maximal cytotoxic concentration: 125000 nM
Beside the measured number, compound 4's estimate is 1.6-fold (0.19 log units) below it, within the range that was stated.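

Going by these compounds alone, compound 4 gives the first readable comparison at this position in this assay: placing 4-bromophenyl where compound 1 has 3,4,5-trimethoxyphenyl on the aromatic carbon gives a 1.2-fold higher number from compound 1 to compound 4 (0.08 log units; within the scatter). The two compounds therefore cannot be told apart by this read-out, even though the exchanged groups differ in their substituents, and this statement rests on a single pair. No accompanying measurement offers any explanation for the result.

Compound 2 and compound 3 have no reported number, so the steps that involve them cannot be read, including the exchange of 2-chlorophenyl for 4-bromophenyl between compound 3 and compound 4. Also open, as far as these compounds go, is whether a group of a different kind at this position, such as an aliphatic amine, a carboxylic acid or a longer alkyl chain, would give a reading that stands clear of those of compound 1 and compound 4.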